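Exocyclic alkene series: hydroxyphenyl variant of compound 1

A few compounds are considered here, and "the series" means these few. Any claim that something is new, unique, unknown or untested is made for them only; others in the source may bear on it.

Compound 1 `Cc1ccc(-c2cn(C/C=C3\OC(=O)C(OCc4ccccc4)=C3OCc3ccccc3)nn2)cc1` is the member of the series with the exocyclic alkene link between the lactone core and the five-membered aromatic ring with 3 nitrogen. In a functional assay on A549 cells (Homo sapiens) for antiproliferative activity, read by MTT assay, with a stated time of 72 h (on this read-out lower numbers stand for stronger inhibition and higher numbers for weaker inhibition), compound 1 returns only a limit, > 100000 nM, not a number. Its position on the scale is therefore the edge of the assay, marked by the limit of > 100000 nM in this assay, at which 1 of the 2 values shown sits. For the measured compounds named here, compound 2 `Cc1ccc(-c2cn(C[C@H](O)[C@H]3OC(=O)C(OCc4ccccc4)=C3OCc3ccccc3)nn2)cc1` gives a measured number in this assay, 8690 nM; no computed step between compound 1 and compound 2 is available, so the two values are taken only as they stand.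

Compound 3 `O=C1O/C(=C\Cn2cc(-c3cccc(O)c3)nn2)C(OCc2ccccc2)=C1OCc1ccccc1` keeps the core of compound 1 and differs from it in one place: 3-hydroxyphenyl in place of 4-methylphenyl on an aromatic carbon. Going by the values given here, no measured pair carries this change. For compound 3 the expected step from its parent is a number no higher from compound 1 to compound 3 (the limit leaves the size open), none beyond the scatter, and a further limit is judged the most likely read-out. Compound 3 is accordingly estimated at 100000 nM, within a range from 30000 nM to 300000 nM.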

Compound 3, half-maximal inhibitory concentration: 23300 nM
For compound 3 the middle estimate is 4.3-fold (0.63 log units) above the measured one; the measured number lies below the stated range.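

Within the exocyclic alkene series, the aromatic carbon of the five-membered aromatic ring with 3 nitrogen now has its first readable step: in this assay, 3-hydroxyphenyl in place of 4-methylphenyl gives an at least 4.2-fold lower number from compound 1 to compound 3 (0.63 log units; beyond the scatter). The substituent on this aryl group therefore matters, since this single change, with the core of compound 1 kept, turns a read-out at the edge of the assay into a measured number. Compound 1 stays a limit of the assay and not a number, so the step has a lower bound only and its full size remains open: the limit of > 100000 nM in this assay, at which 1 of the 3 values shown sits.

The exchange changes the substituent and its place on the phenyl ring together, so a 4-hydroxyphenyl or 3-methylphenyl group at this carbon would be needed to tell the two apart, and a 3-aminophenyl or 3-methoxyphenyl group to show whether the hydroxyl itself is required. Going by these compounds, whether 3-hydroxyphenyl has a comparable effect on the hydroxyl-bearing link of compound 2 also remains open.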